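The source may report more compounds than this note shows. Statements on the series, on what has been measured and on what is new or still open speak of the compounds shown alone.

Of the compounds shown here, three from this series have been measured so far, all sharing the same spiro core and differing only in the group carried on the side-chain amide. Compound 1 `CCOC(=O)C1CCN(C(=O)CN2CN(c3ccccc3)C3(CCN(C(=O)c4ccc(C5CCCCC5)cc4)CC3)C2=O)CC1` gives 900 nM in an assay on HEK293 cells for displacement of a labelled ligand from NPC1-like intracellular cholesterol transporter 1 (Homo sapiens); on this read-out lower numbers stand for stronger inhibition and higher numbers for weaker inhibition. Among the measured compounds shown here, compound 3 `COC(=O)CCNC(=O)CN1CN(c2ccccc2)C2(CCN(C(=O)c3ccc(C4CCCCC4)cc3)CC2)C1=O` gives 12900 nM; the single change between them, (2-(methoxycarbonyl)ethyl)amino in place of 4-(ethoxycarbonyl)piperidin-1-yl on a carbonyl carbon, gives a 14-fold higher number from compound 1 to compound 3 (1.16 log units; beyond the scatter). Compound 2 `CC(C)(C)c1ccc(C(=O)N2CCC3(CC2)C(=O)N(CC(=O)NCCN)CN3c2ccccc2)cc1` gives 7000 nM, the second highest of the three numbers: it sits within the scatter of compound 3 and well beyond it from compound 1.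

Compound 4 `CC(C)(C)c1ccc(C(=O)N2CCC3(CC2)C(=O)N(CC(=O)NCCCCCNS(C)(=O)=O)CN3c2ccccc2)cc1` is not yet measured. It differs from compound 2 by 3-(methanesulfonamido)propyl in place of amino on a saturated chain carbon, two bonds along the chain from an amide-type nitrogen. For the measured compounds named here, no measured step covers this exact change; the only step on record, that from compound 1 to compound 3, sits on the same side chain and shows that altering this region can move the number a great deal. The larger group in compound 1 gave the lower number, so a small gain for compound 4 seems plausible, though a change within the scatter is just as likely. Compound 4 is therefore expected to give 4000 nM, within 1500 nM to 12000 nM, a step of a 1.8-fold lower number from compound 2 to compound 4 (0.24 log units; within the scatter).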

Compound 4, half-maximal inhibitory concentration: 5500 nM
For compound 4 the middle estimate is 1.4-fold (0.14 log units) below the measured one, within the range that was stated.
By their numbers in this assay, from the lowest: compound 1; then compounds 4, 2 and 3 (each within the scatter of the next, the first and the last beyond it).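

In this assay, placing 3-(methanesulfonamido)propyl where amino stood, on a saturated chain carbon, two bonds along the chain from an amide-type nitrogen, gives a 1.3-fold lower number from compound 2 to compound 4 (0.10 log units; within the scatter). This position therefore takes a group of 8 heavy atoms in place of a group of 1 heavy atom, with no measurable loss or gain, and the free amino group is not needed to hold the number where it is. The earlier step on this side chain, a 14-fold higher number from compound 1 to compound 3 (1.16 log units; beyond the scatter), was large, so the compounds now show that a change in this region can matter greatly or hardly at all. Still open, as far as these compounds go, is whether a carboxylic acid, or a shorter chain ending in the same methanesulfonamide, would read differently here. No available evidence explains why compound 2 and compound 4 read so alike.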